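The source may report more compounds than this note shows. Statements on the series, on what has been measured and on what is new or still open speak of the compounds shown alone.

For the measured compounds named here, in an ADME assay on HepG2 cells (Homo sapiens) for cytotoxicity, read by luminescence, CellTiter-Glo and ATP content, with a stated time of 72 h (a lower number here means that less compound is needed, a higher number that more compound is needed for the effect), compound 3 `COc1cccc(CNCCCNc2ccnc3cc(-c4ccc(C(F)(F)F)cc4)ccc23)c1O` gives 2210 nM, the lowest of the three numbers so far, with compound 1 `COc1cccc(CNCCCNc2ccnc3cc(Cc4ccc(C#N)cc4)ccc23)c1O` at 7150 nM and compound 2 `COc1ccccc1Oc1ccc2c(NCCCNCc3cccc(OC)c3O)ccnc2c1` at 11200 nM. Compound 4 `COc1cccc(CNCCCNc2ccnc3cc(CCc4ccccc4)ccc23)c1O` carries phenethyl in place of 4-(trifluoromethyl)phenyl on an aromatic carbon. Two measured steps arrive at the same 4-(trifluoromethyl)phenyl group: a 3.2-fold lower number from compound 1 to compound 3 (0.51 log units; beyond the scatter) and a 5.1-fold lower number from compound 2 to compound 3 (0.70 log units; beyond the scatter). Between the two other groups the data show a 1.6-fold higher number from compound 1 to compound 2 (0.19 log units; within the scatter). Read in reverse, those two modest steps suggest that removing 4-(trifluoromethyl)phenyl will give a higher number in this assay, although phenethyl itself is untested. The expected change is a 2.5-fold higher number from compound 3 to compound 4 (0.40 log units; beyond the scatter). Compound 4 is estimated at 5500 nM, with an expected range of 2500 nM to 12000 nM.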

Compound 4, half-maximal effective concentration: 6800 nM
Beside the measured number, compound 4's estimate is 1.2-fold (0.09 log units) below it; low and high end bracket the measured number.
By their numbers in this assay, from the lowest: compound 3; then compounds 4, 1 and 2 (each within the scatter of the next).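

In this assay the step of a 3.1-fold higher number from compound 3 to compound 4 (0.49 log units; beyond the scatter) shows that phenethyl, which also brings a six-membered aromatic ring of carbon only, does not match 4-(trifluoromethyl)phenyl at this aromatic carbon. Phenethyl cannot be told apart from the other two groups, given a 1.6-fold lower number from compound 2 to compound 4 (0.22 log units; within the scatter) and a 1.1-fold lower number from compound 1 to compound 4 (0.02 log units; within the scatter), so compound 3 alone stands apart among the four. Nothing measured gives a reason for these steps. On these data alone, it remains open whether the gap depends on the trifluoromethyl group itself, and how a plain phenyl, an amine or a carboxylic acid would read at this position.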